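Swapping a Carbonyl Link for a Sulfonyl Link

The source may hold more compounds than are shown below. What is called first, only, known or untested is meant among the compounds shown, and "the series" means these compounds.

Of the compounds shown here, three sharing one core have been tested in an ADME assay on HepG2 2.2.15 cells (Homo sapiens) for cytotoxicity; on this read-out lower numbers stand for higher toxicity in this test and higher numbers for lower toxicity in this test. Compound 1, `CC(C)(C)OC(=O)Nc1ncc(C(Oc2ccc3cc(Br)ccc3c2)c2ccc(Cl)cc2)s1`, sits at a limit of the assay: in this assay compound 1 gives > 50000 nM. Compound 2, `COCCNc1ncc(C(Oc2ccc3cc(Br)ccc3c2)c2ccc(Cl)cc2)s1`, is described in this assay only as "not toxic" (no number reported). Compound 3, `O=C(Nc1ncc(C(Oc2ccc3cc(Br)ccc3c2)c2ccc(Cl)cc2)s1)c1ccc(F)cc1`, is likewise reported in this assay as "not toxic" (no number reported), with no single number attached. So compound 3 stands among entries that all point to low toxicity, yet none of them pins down a value; the only concrete anchor is the limit of > 50000 nM in this assay, at which 1 of the 3 values shown sits.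

Compound 4, `O=S(=O)(Nc1ncc(C(Oc2ccc3cc(Br)ccc3c2)c2ccc(Cl)cc2)s1)c1ccc(Cl)nc1`, has not yet been measured. It differs from compound 3 in one place: (6-chloropyridin-3-yl)sulfonyl in place of (4-fluorophenyl)carbonyl on a nitrogen on an aromatic ring. Going by the values given here, no step between measured compounds exists here, so the size of this change cannot be read from any pair; with every reported value sitting at or beyond the point where toxicity stops being seen, the expectation is no shift beyond the usual scatter in this assay, and most likely another entry of the same kind.

Compound 4 is therefore expected to give about 50000 nM in this assay, with an estimated range from 20000 nM to 100000 nM.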

Compound 4, half-maximal cytotoxic concentration: "not toxic" (no number reported)
The entry for compound 4 holds no number, so the estimate cannot be set against anything.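

In this assay, going by these compounds alone, compound 3 and compound 4 are both described only as "not toxic", with no number, so no step between them can be read. The only figure is a limit, not a number: the limit of > 50000 nM in this assay, at which 1 of the 4 values shown sits. The compounds shown leave open whether they differ in toxicity at all, and at what concentration any toxicity would appear.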